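A few compounds are considered here, and "the series" means these few. Any claim that something is new, unique, unknown or untested is made for them only; others in the source may bear on it.

In a functional assay on HL-60 cells (Homo sapiens) for inhibition, read by MTT assay, with a stated time of 72 h (on this read-out higher numbers stand for weaker inhibition and lower numbers for stronger inhibition), compound 1 `Cc1nc(-c2ccccc2)c(C(=O)N2CCN(c3cccc(Cl)c3Cl)CC2)o1` gives 133 nM, and compound 2 `Cc1nc(-c2cccc(F)c2)c(C(=O)N2CCN(c3cc(Cl)cc(Cl)c3)CC2)o1` gives 41.7 nM. Compound 3 `C=C(C)c1ccc(N2CCN(C(=O)c3oc(C)nc3-c3ccccc3)CC2)cc1` is recorded in this assay as "not active" (no number reported), with no number given, so it stands apart from both on the numbers shown. Compound 4 `Cc1nc(-c2ccccc2)c(C(=O)N2CCN(c3cc(Cl)cc(Cl)c3)CC2)o1` differs from compound 3 by 3,5-dichlorophenyl in place of 4-(1-methylethenyl)phenyl on an amine nitrogen in a ring. For the measured compounds named here, no measured step covers this exact change, but compound 2, which carries the same 3,5-dichlorophenyl on the ring nitrogen, gives 41.7 nM, so a large step toward stronger inhibition is expected in this assay. Compound 4 is estimated to give 70 nM in this assay, expected to lie between 25 nM and 250 nM.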

Compound 4, half-maximal inhibitory concentration: 41.8 nM
Compound 4: middle estimate off by 1.7-fold (0.22 log units), on the high side; low and high end bracket the measured number.
By their numbers in this assay, from the lowest: compounds 2 and 4 (each within the scatter of the next); then compound 1.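

In this assay, 3,5-dichlorophenyl in place of 2,3-dichlorophenyl on the amine nitrogen in the ring gives a 3.2-fold lower number from compound 1 to compound 4 (0.50 log units; beyond the scatter), so where the two chlorines stand on this group alters the number modestly. With 3,5-dichlorophenyl in place, hydrogen in place of fluoro on an aromatic carbon gives a 1.0-fold higher number from compound 2 to compound 4 (0.00 log units; within the scatter), so this change does not separate the two compounds. No measurement shown here explains either step. The compounds shown leave open what a single chlorine, a methoxy or an amine would give in place of the two chlorines.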